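The source may report more compounds than this note shows. Statements on the series, on what has been measured and on what is new or still open speak of the compounds shown alone.

Compound 1 `O=c1cc(-c2ccccc2)oc2cc(OCc3ccccc3)c(OCCCCN3CCCCC3)c(O)c12`: 2400 nM; compound 2 `O=c1cc(-c2ccccc2)oc2cc(OCc3ccccc3)c(OCCCN3CCCCC3)c(O)c12`: 2200 nM; compound 3 `COc1cc2oc(-c3ccccc3)cc(=O)c2c(O)c1OCCCN1CCCCC1`: 22300 nM; all in a functional assay on HepG2 cells (Homo sapiens) for antiproliferative activity, read by MTT assay, with a stated time of 48 h; a lower number here means a stronger inhibitor, a higher number a weaker inhibitor.

Compound 2 gives the lowest of the three numbers, though a 1.1-fold lower number from compound 1 to compound 2 (0.04 log units; within the scatter) is within the scatter, while a 10-fold higher number from compound 2 to compound 3 (1.01 log units; beyond the scatter) is large. Compound 4 `O=c1cc(-c2ccccc2)oc2cc(OCc3ccccc3)c(OCCCN3CCCC3)c(O)c12` differs from compound 2 only at the amine end of the chain: pyrrolidin-1-yl in place of piperidin-1-yl on a saturated chain carbon, three bonds along the chain from an oxygen on an aromatic ring. Among the measured compounds shown here, no measured step changes this ring. For the measured compounds named here, the only change near it, a 1.1-fold lower number from compound 1 to compound 2 (0.04 log units; within the scatter), shifted the number little, and the phenyl that drove the large step is untouched. So compound 4 is expected to stay close to compound 2, with a 1.1-fold higher number from compound 2 to compound 4 (0.06 log units; within the scatter), giving an estimated 2500 nM (range 1000 nM to 6500 nM) in this assay.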

Compound 4, half-maximal inhibitory concentration: 4200 nM
Compound 4: middle estimate off by 1.7-fold (0.23 log units), on the low side; the range from low to high includes it.
By their numbers in this assay, from the lowest: compounds 2, 1 and 4 (each within the scatter of the next); then compound 3.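

In this assay, among the compounds shown here, this is the first change to the ring at the amine end of the chain, and pyrrolidin-1-yl in place of piperidin-1-yl gives a 1.9-fold higher number from compound 2 to compound 4 (0.28 log units; within the scatter). Pyrrolidin-1-yl in place of (piperidin-1-yl)methyl gives a 1.8-fold higher number from compound 1 to compound 4 (0.24 log units; within the scatter), so among compound 1, compound 2 and compound 4 neither change at this position moves the number beyond the scatter. No available evidence bears on this result.

As far as these compounds go, it remains open whether a morpholine ring or an open-chain dimethylamino group at the end of the chain would keep the number in this range. Also open, from the compounds shown here alone, is how pyrrolidin-1-yl would behave on a longer chain, such as a pentyl linker.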